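Compound 2 to compound 3: an amino group replaced

This account rests on a few compounds, and the source may have more. Where it says the series, first, only, none or still open, it means among the compounds named here.

Measured so far in a physicochemical assay for solubility, in phosphate buffer, at pH 6.5 (a lower number here means a less soluble compound, a higher number a more soluble compound), are two compounds:
- Compound 1 `C=C[C@@H]1C[C@]1(NC(=O)[C@@H]1C[C@@H](Oc2nccc3cc(OC)ccc23)CN1C(=O)[C@@H](NC(=O)N[C@H](C(=O)OC(C)(C)C)C(C)(C)C)C(C)(C)C)C(=O)NS(=O)(=O)C1CC1` gives 1 ug/mL
- Compound 2 `C=C[C@@H]1C[C@]1(NC(=O)[C@@H]1C[C@@H](Oc2nccc3cc(OC)ccc23)CN1C(=O)[C@@H](NC(=O)N[C@H](C(N)=O)C(C)(C)C)C(C)(C)C)C(=O)NS(=O)(=O)C1CC1` gives 557 ug/mL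

Compound 2 holds the higher of these two numbers, and its value of 557 ug/mL stands well clear of the scatter. Compound 3 `C=C[C@@H]1C[C@]1(NC(=O)[C@@H]1C[C@@H](Oc2nccc3cc(OC)ccc23)CN1C(=O)[C@@H](NC(=O)N[C@H](C(=O)N1CCN(c2ncccn2)CC1)C(C)(C)C)C(C)(C)C)C(=O)NS(=O)(=O)C1CC1` differs from it in one place, with 4-(pyrimidin-2-yl)piperazin-1-yl in place of amino on a carbonyl carbon. Among the compounds with values here, the only measured step at such a carbonyl carbon is a 560-fold higher number from compound 1 to compound 2 (2.75 log units; beyond the scatter) and it is large, with amino in place of tert-butoxy. Within the data shown here, compound 3 gives up that same amino, although no measured compound carries the group that enters. A large fall in this assay is therefore expected, resting on this single pair. The expected step is a 28-fold lower number from compound 2 to compound 3 (1.44 log units; beyond the scatter) and remains uncertain in size. For compound 3 the estimate is 20 ug/mL within an expected range of 2 ug/mL to 150 ug/mL.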

Compound 3, solubility: 132 ug/mL
Compound 3: middle estimate off by 6.6-fold (0.82 log units), on the low side; the range from low to high includes it.
By their numbers in this assay, from the lowest: compound 1; then compound 3; then compound 2.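

In this assay, swapping amino for the much larger 4-(pyrimidin-2-yl)piperazin-1-yl on this carbonyl carbon gives a 4.2-fold lower number from compound 2 to compound 3 (0.63 log units; beyond the scatter) and is only a modest step, although the entering group brings 12 heavy atoms and two rings in place of a single nitrogen. The other comparison gives a 130-fold higher number from compound 1 to compound 3 (2.12 log units; beyond the scatter) and is large, so a high number in this series is not confined to the compound with amino. The entering group has no hydrogen-bond donor, which shows that such a donor in the group on this carbonyl carbon is not required for a number far above that of compound 1.

The compounds shown do not separate the contribution of the piperazine ring from that of the pyrimidine ring. Nor do they show how a methylamino group or a carboxylic acid would behave on this carbon. No measurement available here accounts for the order of the three compounds.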